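Extending the Sulfur Side Chain of a Thromboxane Synthase Inhibitor

The source may hold more compounds than are shown below. What is called first, only, known or untested is meant among the compounds shown, and "the series" means these compounds.

Compound 3 `COCC(CCC/C=C(\c1ccccc1)c1cccnc1)C(=O)O` gives 41 nM in an assay (Equus caballus) for inhibition of Thromboxane-A synthase (Homo sapiens), using microsomes (a higher number here means a weaker inhibitor, a lower number a stronger inhibitor), the second highest number among the three measured compounds. Compound 1 `CSC(CCC/C=C(\c1ccccc1)c1cccnc1)C(=O)O` gives 30 nM and compound 2 `CC(C)(O)C(CCC/C=C(\c1ccccc1)c1cccnc1)C(=O)O` gives 42 nM; the steps of a 1.4-fold higher number from compound 1 to compound 3 (0.14 log units; within the scatter) and a 1.0-fold lower number from compound 2 to compound 3 (0.01 log units; within the scatter) both lie within the scatter, as does a 1.4-fold higher number from compound 1 to compound 2 (0.15 log units; within the scatter). Compound 4 `CC(C)CSC(CCC/C=C(\c1ccccc1)c1cccnc1)C(=O)O` carries isobutylsulfanyl in place of methoxymethyl on a saturated chain carbon bound to a carbonyl carbon and a saturated chain carbon. The step of a 1.4-fold higher number from compound 1 to compound 3 (0.14 log units; within the scatter) bears most on this change: compound 1 also carries a sulfur group at this place, and that step stayed within the scatter. Among the measured compounds shown here, no measured step covers lengthening of the sulfur chain itself. The expected step in this assay is therefore a 1.3-fold lower number from compound 3 to compound 4 (0.11 log units; within the scatter), none beyond the scatter. Compound 4 is estimated at 32 nM, between 12 nM and 85 nM.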

Compound 4, half-maximal inhibitory concentration: 110 nM
For compound 4 the middle estimate is 3.4-fold (0.54 log units) below the measured one, and the stated range ends below it.
By their numbers in this assay, from the lowest: compounds 1, 3 and 2 (each within the scatter of the next); then compound 4.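

At this saturated chain carbon the earlier groups all stayed within the scatter of one another, but isobutylsulfanyl moves the number beyond it in this assay, both against methoxymethyl (a 2.7-fold higher number from compound 3 to compound 4 (0.43 log units; beyond the scatter)) and against 1-hydroxy-1-methylethyl (a 2.6-fold higher number from compound 2 to compound 4 (0.42 log units; beyond the scatter)). The closest comparison keeps the sulfur and adds isopropyl on the carbon bound to it (a 3.7-fold higher number from compound 1 to compound 4 (0.56 log units; beyond the scatter)), so here the longer sulfur chain gives a weaker inhibitor. Sulfur at this place therefore does not by itself keep the number low.

Nothing available explains this loss. On these data alone, whether an ethylsulfanyl chain would give a number nearer compound 1 or compound 4 stays open.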